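Adding a Hexenyl Ether to Compound 2

The source may report more compounds than this note shows. Statements on the series, on what has been measured and on what is new or still open speak of the compounds shown alone.

Compound 1 `C=CCCCCCOc1ncc(-c2ccccc2OCCCCC=C)n1C`: 70000 nM
Compound 2 `Cn1c(-c2ccccc2O)cnc1S(=O)(=O)c1ccccc1`: > 100000 nM (a limit)

In a functional assay on PC-3 cells (Homo sapiens) for inhibition, read by colorimetric assay and MTT assay, with a stated time of 72 h (a higher number here means a weaker inhibitor, a lower number a stronger inhibitor), compound 2 gives > 100000 nM, which is a limit of the assay and not a number. Compound 3 `C=CCCCCOc1ccccc1-c1cnc(S(=O)(=O)c2ccccc2)n1C` is compound 2 with hex-5-en-1-yl in place of hydrogen on an oxygen on an aromatic ring, so hydroxy becomes (hex-5-en-1-yl)oxy: hex-5-en-1-yl in place of hydrogen on an oxygen on an aromatic ring. Going by the values given here, compound 1 carries the same (hex-5-en-1-yl)oxy group and gives 70000 nM, the only actual number available. Among the compounds with values here, no measured step isolates this change, so the expectation rests on that single value and points to a modest shift towards stronger inhibition in this assay. The expected change is an at least 1.6-fold lower number from compound 2 to compound 3 (0.22 log units; that floor lies within the scatter). The estimate for compound 3 is 60000 nM, with an expected range of 20000 nM to 100000 nM.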

Compound 3, half-maximal inhibitory concentration: 33000 nM
Estimate against measurement, compound 3: 1.8-fold (0.26 log units) above; the range from low to high includes it.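

In this assay, going by these compounds alone, turning hydroxy into (hex-5-en-1-yl)oxy gives an at least 3.0-fold lower number from compound 2 to compound 3 (0.48 log units; beyond the scatter), the first reading of this change on the oxygen, and the size it shows is only a bound. Compound 2 carries a limit of the assay and not a number: the limit of > 100000 nM in this assay, at which 1 of the 3 values shown sits.

With the (hex-5-en-1-yl)oxy group held constant, the other site matters too: phenylsulfonyl in place of (hept-6-en-1-yl)oxy on an aromatic carbon gives a 2.1-fold lower number from compound 1 to compound 3 (0.33 log units; beyond the scatter), a modest step.

Going by these compounds, whether the step on the oxygen depends on the hex-5-en-1-yl chain as such stays open, since a methyl ether or a saturated hexyl chain on the same oxygen would separate chain length from the double bond. Also open, on these data alone, is what an amine or a carboxylic acid at the end of that chain would do.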